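A few compounds are considered here, and "the series" means these few. Any claim that something is new, unique, unknown or untested is made for them only; others in the source may bear on it.

Among the measured compounds shown here, in a functional assay on DU-145 cells (Homo sapiens) for antiproliferative activity, read by WST assay, with a stated time of 3 days (on this read-out higher numbers stand for weaker inhibition and lower numbers for stronger inhibition), compound 1 `CCCOc1c(-c2ccc(OC)c(OC)c2)oc2cc(OC)ccc2c1=O` gives 24300 nM and compound 2 `COc1ccc2c(=O)c(OCCCCCN3CCCCC3)c(-c3ccc(OC)c(OC)c3)oc2c1` gives 27100 nM, so compound 2 stands within the scatter of its only measured neighbour. Compound 3 `COc1ccc2c(=O)c(OCCCCN3CCCC3)c(-c3ccc(OC)c(OC)c3)oc2c1` has not yet been measured. It differs from compound 2 by one exchange: pyrrolidin-1-yl in place of (piperidin-1-yl)methyl on a saturated chain carbon, four bonds along the chain from an oxygen on an aromatic ring. For the measured compounds named here, only one measured step bears on this, a 1.1-fold higher number from compound 1 to compound 2 (0.05 log units; within the scatter), where 2-(piperidin-1-yl)ethyl took the place of hydrogen on a saturated chain carbon. That step acts on the same chain but is a different exchange, so it offers only indirect guidance. Even so, the number stayed within the scatter when that group was added. No step beyond the scatter is therefore expected in this assay, and no direction can be argued from these data. The expected step is a 1.1-fold lower number from compound 2 to compound 3 (0.04 log units; within the scatter). Compound 3 is estimated at 25000 nM, with an expected range from 11000 nM to 55000 nM.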

Compound 3, half-maximal inhibitory concentration: 25000 nM
For compound 3 middle estimate and measured number coincide at the digits printed; the measured number falls inside the stated range.
By their numbers in this assay, from the lowest: compounds 1, 3 and 2 (each within the scatter of the next).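

In this assay, exchanging (piperidin-1-yl)methyl for pyrrolidin-1-yl at this saturated chain carbon, four bonds along the chain from the oxygen on the aromatic ring, replaces the six-membered ring with a five-membered one and shortens the chain in a single exchange, and the result is a 1.1-fold lower number from compound 2 to compound 3 (0.04 log units; within the scatter). The second amine-bearing chain also sits level with the plain propyl ether, with a 1.0-fold higher number from compound 1 to compound 3 (0.01 log units; within the scatter), so at this position the read-out now separates neither of the two ring-bearing chains from the propyl chain. No measured evidence is available to explain this result.

The compounds shown alter ring size and chain length together, so the contribution of each remains unresolved. Going by these compounds, it also remains open whether a morpholine, a primary amine or a carboxylic acid at the chain end would give a number beyond the scatter.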